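A few compounds are considered here, and "the series" means these few. Any claim that something is new, unique, unknown or untested is made for them only; others in the source may bear on it.

Working notes on the series, read in an ADME assay on cells (spleen, Mus musculus, strain C57BL/6) for inhibition, read by flow cytometry and propidium iodide staining, with a stated time of 24 h, at 37 degrees C; on this read-out lower numbers stand for an effect already at smaller amounts and higher numbers for an effect only at larger amounts of compound. Going by the values given here, compound 1 (`CC(C)(O)c1cn(CC(=O)NCc2ccccc2)nn1`) gives 1600 uM, the only plain number so far. Compound 2 (`O=C(Cn1cc(-c2cccc(F)c2)nn1)NCc1ccccc1`) is recorded as "non-toxic" (no number reported). Compound 3 (`O=C(Cn1nncc1CO)NCc1ccccc1`) gives > 2000 uM, and this is a limit of the assay, not a number. Compound 3 therefore stands at the limit of > 2000 uM in this assay, at which 1 of the 3 values shown sits.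

Compound 4 (`COc1cccc(-c2cnnn2CC(=O)NCc2ccccc2)c1`) has not yet been measured. It carries 3-methoxyphenyl in place of hydroxymethyl on an aromatic carbon, on the five-membered aromatic ring with 3 nitrogen: 3-methoxyphenyl in place of hydroxymethyl on an aromatic carbon. Among the compounds with values here, no measured step between compounds differing in one place is available to size this change, so the expectation rests on thin ground. Compound 2 also has a six-membered aromatic ring of carbon only on its five-membered ring, and it is recorded as "non-toxic" (no number reported), which gives no sign of a large effect. Compound 1 gives 1600 uM, which marks the only measured level in this assay. A modest step toward an effect at smaller amounts is expected, and it may not clear the usual scatter: the expected step is an at least 1.6-fold lower number from compound 3 to compound 4 (0.22 log units; that floor lies within the scatter). For compound 4 the estimate is 1200 uM, with an expected range from 400 uM to 2500 uM.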

Compound 4, concentration for half-maximal effect: > 2000 uM
Compound 4 was reported as a limit; the forecaster's own chance of this, stated with the estimate: 45%; at least 1.6-fold (0.22 log units) between middle value and limit.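

In this assay compound 3 and compound 4 are both recorded only as limits, so no step can be read between them for 3-methoxyphenyl in place of hydroxymethyl on an aromatic carbon. The compounds shown leave open where either compound would fall beyond its limit, and whether this change shifts the read-out at all.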